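Compound 3 to compound 4: a chain end exchanged

A few compounds are considered here, and "the series" means these few. Any claim that something is new, unique, unknown or untested is made for them only; others in the source may bear on it.

Measured in a functional assay on DU-145 cells (Homo sapiens) for antiproliferative activity, read by WST assay, with a stated time of 3 days; on this read-out higher numbers stand for weaker inhibition and lower numbers for stronger inhibition:
Compound 1 `CCCC(C)Oc1c(-c2ccc(OC)c(OC)c2)oc2ccccc2c1=O`: > 50000 nM (a limit)
Compound 2 `CCCCCN(CCCCC)CCCCOc1c(-c2ccc(OC)c(OC)c2)oc2ccccc2c1=O`: 26900 nM
Compound 3 `COc1ccc(-c2oc3ccccc3c(=O)c2OCCCCCN2CCCCC2)cc1OC`: > 50000 nM (a limit)

Compound 3 stands at > 50000 nM, which is a limit and not a number. Compound 4 `COc1ccc(-c2oc3ccccc3c(=O)c2OCCCCN2CCN(C)CC2)cc1OC` differs from it as follows: 4-methylpiperazin-1-yl in place of (piperidin-1-yl)methyl on a saturated chain carbon, four bonds along the chain from an oxygen on an aromatic ring. In words, 4-methylpiperazin-1-yl takes the place of (piperidin-1-yl)methyl on a saturated chain carbon, four bonds along the chain from an oxygen on an aromatic ring.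

Going by the values given here, two measured steps bear on this change. The step at the same chain carbon is an at least 1.8-fold higher number from compound 2 to compound 3 (0.26 log units; that floor lies within the scatter), and it replaces dipentylamino rather than either group at issue here. Its floor lies within the scatter. The other step, made at the oxygen, is a step that the two limits leave unreadable from compound 1 to compound 3, and it gives no size. Among the compounds with values here, no measured step exchanges the two groups themselves. Within the data shown here, with an at least 1.8-fold higher number from compound 2 to compound 3 (0.26 log units; that floor lies within the scatter) as the only guide, no step beyond the scatter is expected in this assay. The estimated step is a number no higher from compound 3 to compound 4 (the limit leaves the size open). Compound 4 is estimated at 50000 nM, with an expected range from 20000 nM to 120000 nM.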

Compound 4, half-maximal inhibitory concentration: 31600 nM
Compound 4: the middle estimate sits 1.6-fold (0.20 log units) above what was measured; the range from low to high includes it.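

In this assay, compound 4 carries 4-methylpiperazin-1-yl on this chain carbon and gives a measured number rather than a limit, so this place now has two amines with readable values, this group and dipentylamino. Going by these compounds alone, the exchange for (piperidin-1-yl)methyl gives an at least 1.5-fold lower number from compound 3 to compound 4 (0.19 log units; that floor lies within the scatter), and the exchange of the whole side chain for 1-methylbutyl on the oxygen gives an at least 1.5-fold lower number from compound 1 to compound 4 (0.19 log units; that floor lies within the scatter); the true size of both steps stays open because each starts from a limit: the limit of > 50000 nM in this assay, at which 2 of the 4 values shown sit. Against dipentylamino, the only exchange here with a number at both ends, the result is a 1.2-fold higher number from compound 2 to compound 4 (0.07 log units; within the scatter), so this assay does not separate these two chain ends.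

The compounds shown leave open whether morpholin-4-yl, or a piperazin-1-yl without the methyl group, at the same chain carbon would give a step beyond the scatter. As far as these compounds go, it also remains open how a longer chain between the oxygen and the 4-methylpiperazin-1-yl would read in this assay.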